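The source may hold more compounds than are shown below. What is called first, only, known or untested is meant among the compounds shown, and "the series" means these compounds.

Measured in an ADME assay on Huh-7 cells (Homo sapiens) for cytotoxicity, with a stated time of 72 h; a higher number here means that more compound is tolerated, a lower number that less compound is tolerated:
- compound 1 `COCCn1nc(-c2cccs2)c(O)c(C2=NS(=O)(=O)c3cc(NS(C)(=O)=O)ccc3N2)c1=O`: > 1000 nM
- compound 2 `COC(C)(C)CCn1nc(-c2cccs2)c(O)c(C2=NS(=O)(=O)c3cc(NS(C)(=O)=O)ccc3N2)c1=O`: > 33000 nM
- compound 3 `CS(=O)(=O)Nc1ccc2c(c1)S(=O)(=O)N=C(c1c(O)c(-c3cccs3)nn(CC3CC3)c1=O)N2`: > 1000 nM

Each of these three entries is a limit of the assay and not a number, so the series offers no measured value to build on.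

Compound 3 stands only at a limit, > 1000 nM. The next compound, compound 4 `CS(=O)(=O)Nc1ccc2c(c1)S(=O)(=O)N=C(c1c(O)c(-c3cccs3)nn(CC3(C(F)(F)F)CCC3)c1=O)N2`, keeps the shared core and alters the group on a saturated chain carbon bound to an aromatic nitrogen: 1-(trifluoromethyl)cyclobutyl in place of cyclopropyl on a saturated chain carbon bound to an aromatic nitrogen. In words, 1-(trifluoromethyl)cyclobutyl takes the place of cyclopropyl.

Three measured changes fall at this same part of the molecule. Among the compounds with values here, the first is a step that the two limits leave unreadable from compound 1 to compound 3. The second is a step that the two limits leave unreadable from compound 2 to compound 3. The third is a step that the two limits leave unreadable from compound 1 to compound 2. None of them has a readable size, and none involves the 1-(trifluoromethyl)cyclobutyl group, so the series supplies no direction for this change. In this assay, no shift beyond the usual scatter is therefore expected, though this expectation rests on limits alone. The expected size of the change is a step that the limit leaves unreadable from compound 3 to compound 4. For compound 4 the estimated value is 10000 nM, with an expected range from 1000 nM to 50000 nM.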

Compound 4, half-maximal cytotoxic concentration: > 1000 nM
Compound 4: only a limit was reported (the forecaster's own chance of this, stated with the estimate: 85%); the middle value does not contradict the limit.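

In this assay compound 4 gives > 1000 nM, which is a limit and not a number. Within the data shown here, compound 1, compound 2 and compound 3 also stand only at limits, so no step to compound 4 can be read. The compounds shown leave open whether the groups on the saturated chain carbon differ at all in this assay.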